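Working notes: two measured compounds and one to be measured

The source may report more compounds than this note shows. Statements on the series, on what has been measured and on what is new or still open speak of the compounds shown alone.

Measured so far:
compound 1 `O=C1Nc2ccc(S(=O)(=O)N3CCOCC3)cc2/C1=N/NC(=O)c1ccccc1`: 18100 nM
compound 2 `O=C1Nc2ccc(S(=O)(=O)N3CCOCC3)cc2/C1=N/c1ccc(Br)cc1`: 11900 nM

In a functional assay on HepG2 cells (Homo sapiens) for cytotoxicity, read by sulforhodamine B assay, with a stated time of 24 h (on this read-out lower numbers stand for stronger inhibition and higher numbers for weaker inhibition), compound 1 gives 18100 nM and compound 2 gives 11900 nM. Compound 2 stands with compound 1 inside the usual scatter: the step of a 1.5-fold lower number from compound 1 to compound 2 (0.18 log units; within the scatter) does not separate the two. Compound 3 `O=C1Nc2ccc(S(=O)(=O)N3CCOCC3)cc2/C1=N/Nc1ccccc1` is the next to be measured; it differs from compound 2 by anilino in place of 4-bromophenyl on a double-bonded nitrogen. Among the compounds with values here, the only measured step that bears on this change is the one from compound 1 to compound 2, a swap of the group on the same double-bonded nitrogen, and that step stayed within the scatter. Nothing else measured touches this place. In this assay a step of about that size is therefore expected, a 1.2-fold higher number from compound 2 to compound 3 (0.07 log units; within the scatter), with no direction that the data can support. Compound 3 is expected to give 14000 nM, with a range from 5000 nM to 40000 nM.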

Compound 3, half-maximal inhibitory concentration: 15600 nM
Beside the measured number, compound 3's estimate is 1.1-fold (0.05 log units) below it, within the range that was stated.
By their numbers in this assay, from the lowest: compounds 2, 3 and 1 (each within the scatter of the next).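

In this assay the anilino group gives a 1.3-fold higher number from compound 2 to compound 3 (0.12 log units; within the scatter) and so joins 4-bromophenyl and benzamido as a third group on this double-bonded nitrogen that is not separated from the others. Anilino brings a hydrogen-bond donor and a hydrogen-bond acceptor that 4-bromophenyl lacks and has nitrogen in place of bromine at the same heavy-atom count, yet the step stays within the scatter. Phenyl in place of benzoyl on the amine nitrogen gives a 1.2-fold lower number from compound 1 to compound 3 (0.06 log units; within the scatter) and likewise leaves the number unseparated, so neither swap shows a dependence on the group at this place. No available evidence bears on a cause for these results.

As far as these compounds go, whether a carboxylic acid, an amine or a longer alkyl chain on this nitrogen would move the number beyond the scatter stays open. From the compounds shown here alone, the effect of any change to the shared core also stays open, since all three compounds carry it unchanged.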